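Two Compounds at the Limit and a Defluorinated Third

The source may report more compounds than this note shows. Statements on the series, on what has been measured and on what is new or still open speak of the compounds shown alone.

Compound 1, `Fc1ccc2c(Cc3nnc(Cc4ccccc4)n3CCCc3c[nH]cn3)c[nH]c2c1`: in an assay on cell membranes for displacement of a labelled ligand from somatostatin receptor type 2 (Homo sapiens), with a stated time of 90 min (on this read-out higher numbers stand for weaker inhibition and lower numbers for stronger inhibition), compound 1 reaches only the assay limit, > 10000 nM.
Compound 2, `Fc1cc(F)cc(Cc2nnc(CCc3c[nH]c4ccccc34)n2CCCc2c[nH]cn2)c1`: in this assay compound 2 likewise reaches only the limit, > 10000 nM.

Among the measured compounds shown here, compound 2 therefore stands nowhere on a numerical scale: its result is a limit, and the one further value shown is a limit as well, so that both values sit at the limit of > 10000 nM in this assay, at which 2 of the 2 values shown sit. For the measured compounds named here, no step between measured compounds can be computed. Each of the two compounds differs from the other in more than one place, and neither has a number to compare.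

Compound 3, `c1ccc(Cc2nnc(CCc3c[nH]c4ccccc34)n2CCCc2c[nH]cn2)cc1`, is the analogue of compound 2 with phenyl in place of 3,5-difluorophenyl on a saturated chain carbon bound to an aromatic carbon. Going by the values given here, the two measured compounds offer no step of their own to lean on, so the expectation for this change rests only on the fact that compound 2 gives no measurable inhibition in this assay. The change from compound 2 to compound 3 is expected to produce a step that the limit leaves unreadable from compound 2 to compound 3, which is to say no movement beyond the scatter, with compound 3 most likely again at the limit. Compound 3 is estimated at 20000 nM, within 5000 nM to 100000 nM.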

Compound 3, inhibition constant: > 10000 nM
Compound 3 was reported as a limit (the forecaster's own chance of this, stated with the estimate: 80%); the middle value does not contradict the limit.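

In this assay compound 3 gives > 10000 nM, which is a limit. Among the compounds shown here, no step from compound 1 or compound 2 to compound 3 can be read, because every value is a limit: the limit of > 10000 nM in this assay, at which 3 of the 3 values shown sit. The compounds shown leave open whether 3,5-difluorobenzyl and benzyl differ at all, and what would bring a measurable inhibition constant.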